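This account rests on a few compounds, and the source may have more. Where it says the series, first, only, none or still open, it means among the compounds named here.

Compound 1 (`CS(=O)(=O)N1C[C@H](C(=O)Nc2ccc(Cl)cc2)[C@@H](C(=O)Nc2ccc(-n3ccccc3=O)cc2F)C1`): 2.17
Compound 2 (`O=C(Nc1ccc(Cl)cc1)[C@H]1CN(Cc2ccncc2)C[C@@H]1C(=O)Nc1ccc(-n2ccccc2=O)cc1F`): "not determined" (no result reported)

For the measured compounds named here, in a physicochemical assay for lipophilicity, at pH 7.4 (on this read-out higher numbers stand for higher lipophilicity and lower numbers for lower lipophilicity), compound 1 gives 2.17 as the only number so far, so it cannot yet be ranked against anything. Compound 3 (`CS(=O)(=O)N1C[C@H](C(=O)Nc2ccc3[nH]ccc3c2)[C@@H](C(=O)Nc2ccc(-n3ccccc3=O)cc2F)C1`) keeps the core of compound 1 and differs in one place (1H-indol-5-yl in place of 4-chlorophenyl on an amide-type nitrogen), with 1H-indol-5-yl in place of 4-chlorophenyl on an amide-type nitrogen. Going by the values given here, no measured pair shows such a swap, so the expectation rests on the structural change alone. The expected step in this assay is a modest fall, estimated as a number 0.32 log units lower from compound 1 to compound 3 (beyond the scatter) and perhaps not far beyond the usual scatter. For compound 3 the estimated value is 1.85 with an expected range from 1.45 to 2.25 in the measurement still to come.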

Compound 3, distribution coefficient: 1.07
Compound 3: the middle estimate sits 0.78 log units above what was measured, and the stated range ends above it.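

At this amide-type nitrogen the choice of aromatic group clearly matters: in this assay, 1H-indol-5-yl in place of 4-chlorophenyl gives a number 1.10 log units lower from compound 1 to compound 3 (beyond the scatter), a change that a single swap on the shared core can produce. The entering group also carries a hydrogen-bond donor and loses the chlorine, so the two groups differ in more than one feature. No measurement here says which of these features accounts for the step.

Still open, as far as these compounds go, is how a plain phenyl, or a phenyl carrying an amine or a carboxylic acid, would read at this nitrogen in this assay. Compound 2 has no number to compare.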